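From morpholin-4-yl to (4-methoxycyclohexyl)amino on the carbonyl carbon

This account rests on a few compounds, and the source may have more. Where it says the series, first, only, none or still open, it means among the compounds named here.

In a functional assay on BXPC-3 cells (Homo sapiens) for inhibition, read by MTT assay, with a stated time of 7 days (on this read-out higher numbers stand for weaker inhibition and lower numbers for stronger inhibition), compound 2 `CCN(CC)S(=O)(=O)c1ccc(S(=O)(=O)N2CCC[C@@H](C(=O)N3CCOCC3)C2)cc1` reads 790 nM and compound 3 `CN(C)S(=O)(=O)c1ccc(S(=O)(=O)N2CCC[C@@H](C(=O)N3CCC(F)(F)CC3)C2)cc1` reads 560 nM and these two values lie within the scatter of each other. Compound 1 `CCN(CC)S(=O)(=O)c1ccc(S(=O)(=O)N2CCC[C@@H](C(=O)N3CCC(O)CC3)C2)cc1` reads 4710 nM and stands well apart from compound 2.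

The next compound has not yet been measured. Compound 4 `CCN(CC)S(=O)(=O)c1ccc(S(=O)(=O)N2CCC[C@@H](C(=O)N[C@H]3CC[C@@H](OC)CC3)C2)cc1` carries (4-methoxycyclohexyl)amino in place of morpholin-4-yl on a carbonyl carbon, a difference that counts out as (4-methoxycyclohexyl)amino in place of morpholin-4-yl on a carbonyl carbon in full.

Among the measured compounds shown here, only one measured step bears on this change. It is a 6.0-fold lower number from compound 1 to compound 2 (0.78 log units; beyond the scatter) and it came from morpholin-4-yl replacing 4-hydroxypiperidin-1-yl on that same carbonyl carbon. For the measured compounds named here, that step is modest, and no measured compound carries the entering group, so even the direction is uncertain, with only a slight lean towards a higher number. The expected result is a 1.5-fold higher number from compound 2 to compound 4 (0.18 log units; within the scatter) and the range is kept wide. For compound 4 the estimate in this assay is 1200 nM with an expected range from 350 nM to 4000 nM as its upper end.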

Compound 4, half-maximal inhibitory concentration: 2150 nM
Compound 4: middle estimate off by 1.8-fold (0.25 log units), on the low side; measured number inside the range.
By their numbers in this assay, from the lowest: compounds 3 and 2 (each within the scatter of the next); then compound 4; then compound 1.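

In this assay, the move away from morpholin-4-yl on this carbonyl carbon gives a 2.7-fold higher number from compound 2 to compound 4 (0.43 log units; beyond the scatter), so among these three compounds morpholin-4-yl remains the group with the lowest number. The (4-methoxycyclohexyl)amino group, which adds an amide hydrogen and has a carbon-only ring, still shows a 2.2-fold lower number from compound 1 to compound 4 (0.34 log units; beyond the scatter), placing it between morpholin-4-yl and 4-hydroxypiperidin-1-yl. The position therefore accepts a group with a hydrogen-bond donor on the nitrogen, although nothing shown explains the order of the three groups.

Going by these compounds, compound 4 changes the ring atoms, the amide hydrogen and the methoxy group together, so their separate contributions remain open. A plain cyclohexylamino or 4-methoxypiperidin-1-yl group on the same carbonyl carbon would help separate them, and the role of the two defined stereocentres is also unresolved.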